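Swapping a Carbamate for Isopropyl on the Ring Nitrogen

The source may hold more compounds than are shown below. What is called first, only, known or untested is meant among the compounds shown, and "the series" means these compounds.

Three compounds share one core, a urea-bearing bicyclic amide, and differ only in the group on the amine nitrogen in the ring. In a functional assay (strain AB) with Danio rerio as the target, read by microscopy, with a stated time of 1 h (a higher number here means that more compound is needed for the effect, a lower number that less compound is needed), compound 1 `NC(=O)c1c(NC(=O)Nc2ccc(Cl)cc2)sc2c1CCN(C1CCOCC1)C2` gives 2830 nM. Compound 2 `CN1CCc2c(sc(NC(=O)Nc3ccc(Cl)cc3)c2C(N)=O)C1` gives 4700 nM in this assay, and the change a 1.7-fold higher number from compound 1 to compound 2 (0.22 log units; within the scatter) stays within the scatter. As far as these compounds go, compound 3 `CC(C)(C)OC(=O)N1CCc2c(sc(NC(=O)Nc3ccc(Cl)cc3)c2C(N)=O)C1` reaches only a limit of the assay, > 25000 nM, so its true value is unknown beyond that bound. This limit is shared by the limit of > 25000 nM in this assay, at which 1 of the 3 values shown sits. The steps to compound 3 are the ones that matter here: an at least 8.8-fold higher number from compound 1 to compound 3 (0.94 log units; beyond the scatter) and an at least 5.3-fold higher number from compound 2 to compound 3 (0.72 log units; beyond the scatter), both beyond the scatter. Compound 4 `CC(C)N1CCc2c(sc(NC(=O)Nc3ccc(Cl)cc3)c2C(N)=O)C1` carries isopropyl in place of tert-butoxycarbonyl on an amine nitrogen in a ring. Isopropyl is a plain alkyl group, like the methyl of compound 2 and the oxan-4-yl of compound 1, and both of those compounds gave numbers rather than limits. The step is therefore expected to run in reverse, a clear decrease, an at least 7.1-fold lower number from compound 3 to compound 4 (0.85 log units; beyond the scatter). Compound 4 is estimated at 3500 nM, with a range from 1500 nM to 10000 nM.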

Compound 4, half-maximal effective concentration: 1490 nM
Compound 4: the middle estimate sits 2.3-fold (0.37 log units) above what was measured, outside the stated range (below it).
By their numbers in this assay, from the lowest: compounds 4, 1 and 2 (each within the scatter of the next, the first and the last beyond it). At a limit, above all of these: compound 3.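

Replacing tert-butoxycarbonyl with isopropyl on this amine nitrogen gives an at least 16-fold lower number from compound 3 to compound 4 (1.22 log units; beyond the scatter), but that size is only a floor, because compound 3 stands at a limit: the limit of > 25000 nM in this assay, at which 1 of the 4 values shown sits. The new compound also shows that plain alkyl groups at this position need not behave alike, since a 3.2-fold lower number from compound 2 to compound 4 (0.50 log units; beyond the scatter) lies beyond the scatter, which compounds 1 and 2 alone did not reveal. By contrast, a 1.9-fold lower number from compound 1 to compound 4 (0.28 log units; within the scatter) stays within the scatter, so oxan-4-yl and isopropyl cannot be told apart in this assay.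

Compound 3 is the only one here with a carbonyl on this nitrogen, so the compounds shown cannot say whether an acetyl group would also reach a limit. As far as these compounds go, how an ethyl or cyclopropyl group, or a bare ring amine, would compare also stays open.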